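The source may hold more compounds than are shown below. What is called first, only, known or untested is meant among the compounds shown, and "the series" means these compounds.

Measured so far:
compound 1, `CC(C)C[C@H](NC(=O)N1CCOCC1)C(=O)N[C@H](C#N)CCc1ccccc1`, 47 nM
compound 2, `CCCC[C@@H](C#N)NC(=O)[C@H](CC(C)C)NC(=O)N1CCOCC1`, 56 nM

These two compounds share a core and differ only in the group attached where the chain carbon carries the nitrile. In an assay for inhibition of cathepsin S (Homo sapiens) (on this read-out higher numbers stand for weaker inhibition and lower numbers for stronger inhibition), compound 2 gives the higher of the two numbers, though the step of a 1.2-fold higher number from compound 1 to compound 2 (0.08 log units; within the scatter) lies within the scatter, so the two cannot be told apart on these figures.

Compound 3, `CC(C)C[C@H](NC(=O)N1CCOCC1)C(=O)N[C@H](C#N)C(C)(C)C`, is not yet measured. It differs from compound 2 by tert-butyl in place of butyl on a saturated chain carbon bound to an amide-type nitrogen and a triple-bonded carbon: the same four carbons, now branched rather than in a straight chain. For the measured compounds named here, the only step that bears on this is the one from compound 1 to compound 2, which swapped one chain end for another at a nearby place and produced a change within the scatter. That step says the region tolerates some variation; it says nothing about branching at the carbon right beside the nitrile. The expectation for compound 3 is therefore uncertain, with a mild loss judged somewhat more likely than a gain, expressed by a 2.7-fold higher number from compound 2 to compound 3 (0.43 log units; beyond the scatter). Compound 3 is expected to give about 150 nM in this assay, within a range from 40 nM to 600 nM.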

Compound 3, half-maximal inhibitory concentration: 107000 nM
For compound 3 the middle estimate is 710-fold (2.85 log units) below the measured one; measured number above the stated range.
By their numbers in this assay, from the lowest: compounds 1 and 2 (each within the scatter of the next); then compound 3.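

In this assay, the result shows that this position is far less forgiving than compound 1 and compound 2 suggested, since those two could not be told apart despite carrying quite different groups. Putting tert-butyl in place of butyl on a saturated chain carbon bound to an amide-type nitrogen and a triple-bonded carbon keeps the same atoms and joins them differently, yet it gives a 1900-fold higher number from compound 2 to compound 3 (3.28 log units; beyond the scatter), so here the way the carbons are joined matters, not merely how many there are. The loss also appears when tert-butyl replaces phenethyl, with a 2300-fold higher number from compound 1 to compound 3 (3.36 log units; beyond the scatter), and nothing available here accounts for such a large effect.

The compounds shown leave open how much branching this position can accept, as isopropyl, sec-butyl and neopentyl would each show whether the loss arrives gradually or only with tert-butyl. As far as these compounds go, it also remains open how far the tolerance for unbranched groups extends, for example whether a longer chain such as hexyl would stay within the scatter of compound 1 and compound 2.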